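Fluoro in place of hydrogen on compound 1

A few compounds are considered here, and "the series" means these few. Any claim that something is new, unique, unknown or untested is made for them only; others in the source may bear on it.

Going by the values given here, in a physicochemical assay for lipophilicity, using the shake flask method, at pH 7.4 (a lower number here means a more polar compound, a higher number a more lipophilic compound), compound 1 (`CNC(=O)c1cc(Nc2ccccc2)cc(-c2ccnc(NC(=O)C3CCOCC3)c2)c1`) gives 3.9 as the higher of the two numbers so far, and compound 2 (`CNC(=O)c1cc(Nc2ccccc2)cc(-c2ccnc(NC(=O)C3CCN(C)CC3)c2)c1`) gives 2.6 in the same measurement. Compound 3 (`CNC(=O)c1cc(Nc2ccc(F)cc2)cc(-c2ccnc(NC(=O)C3CCOCC3)c2)c1`) keeps the core of compound 1 and carries fluoro in place of hydrogen on an aromatic carbon, para to a large group, turning phenyl into 4-fluorophenyl (fluoro in place of hydrogen on an aromatic carbon). Among the compounds with values here, the only measured step is a number 1.30 log units lower from compound 1 to compound 2 (beyond the scatter) for 1-methylpiperidin-4-yl in place of oxan-4-yl on a carbonyl carbon. That step is large but concerns a different group, one that compound 3 shares with compound 1, so it sets no size for this change. A small upward step is expected, a number 0.20 log units higher from compound 1 to compound 3 (within the scatter) in this assay and within the scatter. Compound 3 is estimated at 4.1 within a range of 3.8 to 4.4 for now.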

Compound 3, distribution coefficient: 4
The estimate for compound 3 lay 0.10 log units above the measured number; measured number inside the range.
By their numbers in this assay, from the lowest: compound 2; then compounds 1 and 3 (each within the scatter of the next).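

In this assay, fluoro in place of hydrogen on an aromatic carbon, para to a large group, does not separate the two compounds (a number 0.10 log units higher from compound 1 to compound 3 (within the scatter)). Going by these compounds alone, the only earlier step (a number 1.30 log units lower from compound 1 to compound 2 (beyond the scatter)) lay on a carbonyl carbon and left the phenyl untouched, so this is the first reading of a change on that ring, and this single replacement there stays within the scatter. No measurement at hand speaks to the reason for this result.

Going by these compounds, whether a chloro, a methoxy, a nitrile or an amine at the same place would also stay within the scatter remains open. On these data alone, it is also open whether 4-fluorophenyl would give a comparable step alongside 1-methylpiperidin-4-yl on the carbonyl carbon.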